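A few compounds are considered here, and "the series" means these few. Any claim that something is new, unique, unknown or untested is made for them only; others in the source may bear on it.

Compound 1 `CCCCOC(=O)NS(=O)(=O)c1ccc(CCC)cc1-c1ccc(Cn2c(C(C)(C)C)nc3ccccc32)cc1` is the reference point of this short series. In an ADME assay on microsomes from liver (Mus musculus, strain CD-1) for metabolic stability, read by LC-MS, using NADPH, with stated times of 5 min and 60 min, tested at 1 uM (a higher number here means that the compound lasts longer, a lower number that the compound disappears faster), compound 1 gives 0.117 h, and the two other measured compounds lie within the scatter of that number: compound 2 `CCCc1ccc(S(=O)(=O)NC(=O)OCCCC(F)(F)F)c(-c2cc(F)c(Cn3c(C(C)(C)C)nc4ccccc43)c(F)c2)c1` gives 0.1 h and compound 3 `CCCc1ccc(S(=O)(=O)NC(=O)OCCCC(F)(F)F)c(-c2ccc(Cn3c(C(C)(C)C)nc4ccccc43)cc2)c1` gives 0.1 h in this assay, so none of the three can be set apart from the others. Within the data shown here, the one single-point step that has been measured, a 1.2-fold lower number from compound 1 to compound 3 (0.07 log units; within the scatter), concerns the carbamate chain and not the benzimidazole substituent. Compound 4 `CCCCOC(=O)NS(=O)(=O)c1ccc(CCC)cc1-c1ccc(Cn2c(-c3nccs3)nc3ccccc32)cc1` differs from compound 1 by 1,3-thiazol-2-yl in place of tert-butyl on an aromatic carbon. Among the measured compounds shown here, no measured pair changes this group, so the measured steps carry no information on the size or direction of this change. Given that every measured number sits close to compound 1, the working expectation is that compound 4 lands near the same value, with the step from compound 1 estimated as a 1.1-fold lower number from compound 1 to compound 4 (0.03 log units; within the scatter) and no direction beyond the scatter assumed. The estimate for compound 4 in this assay is 0.11 h, within a range of 0.05 h to 0.25 h.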

Compound 4, half-life: 0.0833 h
Estimate against measurement, compound 4: 1.3-fold (0.12 log units) above; the measured number falls inside the stated range.
By their numbers in this assay, from the lowest: compounds 4, 2, 3 and 1 (each within the scatter of the next).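

Among these compounds, this is the first measured step at the aromatic carbon between two ring nitrogen atoms. In this assay, the step is a 1.4-fold lower number from compound 1 to compound 4 (0.15 log units; within the scatter), so 1,3-thiazol-2-yl in place of tert-butyl does not set compound 4 apart from compound 1, even though a five-membered aromatic ring enters where the leaving group had no ring. Nothing in hand bears on the reason for this outcome.

From the compounds shown here alone, it remains open whether any other group at this position, such as an amine, a phenyl ring or a cyclopropyl ring in place of tert-butyl, would give a step beyond the scatter. Going by these compounds, it is also open whether 1,3-thiazol-2-yl would give the same result alongside the carbamate chain of compound 3, which ends in trifluoromethyl.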